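This account rests on a few compounds, and the source may have more. Where it says the series, first, only, none or still open, it means among the compounds named here.

Measured in an ADME assay on cells (Hepatocyte, Homo sapiens) for metabolic stability, read by LC-MS, with a stated time of 60 min; a higher number here means that more of the compound is left, a lower number that less of the compound is left: compound 1 `Cc1nn([C@H](C)c2ccc(Cl)cc2Cl)c2nc(C3=CC[C@H](N4CCC[C@H]4CO)[C@H](C)C3)cnc12` gives 99%; compound 2 `C[C@@H]1CC(c2cnc3c(C#N)nn([C@H](C)c4ccc(Cl)cc4Cl)c3n2)=CC[C@@H]1N1CCC[C@H]1C(N)=O` gives 97%; compound 3 `C[C@@H]1CC(c2cnc3c(C#N)nn([C@H](C)c4ccc(Cl)cc4Cl)c3n2)=CC[C@@H]1N1CCC[C@H]1C` gives 86%.

Compound 3 stands lowest of the three, beyond the scatter from both others. Compound 4 `C[C@@H]1CC(c2cnc3c(C#N)nn([C@H](C)c4ccc(Cl)cc4Cl)c3n2)=CC[C@@H]1N1CCC[C@H]1CO` differs from it by hydroxy in place of hydrogen on a saturated chain carbon bound to a saturated ring carbon. For the measured compounds named here, the one measured step on the shared core, a number 11 percentage points lower from compound 2 to compound 3 (beyond the scatter), shows a carbamoyl on a saturated ring carbon reading higher than a methyl; the hydroxy entering now sits one bond further out on the same ring. Going by the values given here, compound 1, bearing the same hydroxymethyl on a different core, shows the highest value of the three, though no step from it to compound 3 is available. A step upward beyond the scatter is therefore expected for compound 4, around a number 9 percentage points higher from compound 3 to compound 4 (within the scatter). Compound 4 is estimated at 95%, within 85% to 100%.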

Compound 4, percent of the compound remaining: 81%
Estimate against measurement, compound 4: 14 percentage points above; measured number outside the range, below it.
By their numbers in this assay, from the lowest: compounds 4 and 3 (each within the scatter of the next); then compounds 2 and 1 (each within the scatter of the next).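

In this assay, hydroxy in place of hydrogen on a saturated chain carbon bound to a saturated ring carbon gives a number 5 percentage points lower from compound 3 to compound 4 (within the scatter) and so separates 2-(hydroxymethyl)pyrrolidin-1-yl from 2-methylpyrrolidin-1-yl by no more than the scatter. The carbamoyl stands apart from hydroxymethyl too, with a number 16 percentage points lower from compound 2 to compound 4 (beyond the scatter) as the step, so among these three groups only carbamoyl reads higher. With the hydroxymethyl kept, cyano in place of methyl on an aromatic carbon gives a number 18 percentage points lower from compound 1 to compound 4 (beyond the scatter) and shows that the number also depends on that aromatic carbon. Going by these compounds, whether an amine or a carboxylic acid in this place would read with the carbamoyl or with the other two stays open. Nothing at hand explains these steps.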